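Swapping the Amide Aryl Group: Methyl to Nitro

The compounds below may be only part of what the source reports. "The series", "measured", "known", "first", "only" and "open" are said of these compounds alone.

The three measured compounds share one core and differ only in the aryl group of the amide. Compound 1 `NC(=O)c1c(NC(=O)c2ccccc2F)sc2c1CCN(C(=S)Nc1ccccc1Cl)C2` gives 11100 nM in a functional assay on MKN-74 cells (Homo sapiens) for antiproliferative activity, with a stated time of 24 h; a higher number here means a weaker inhibitor, a lower number a stronger inhibitor. Compound 2 `NC(=O)c1c(NC(=O)c2ccccc2C(F)(F)F)sc2c1CCN(C(=S)Nc1ccccc1Cl)C2` gives 21900 nM, and compound 3 `Cc1ccccc1C(=O)Nc1sc2c(c1C(N)=O)CCN(C(=S)Nc1ccccc1Cl)C2` gives 11000 nM. Among these, compound 3 has the lowest of the three numbers, but its steps to the others stay within the scatter: a 1.0-fold lower number from compound 1 to compound 3 (0.00 log units; within the scatter) and a 2.0-fold lower number from compound 2 to compound 3 (0.30 log units; within the scatter). The remaining step, a 2.0-fold higher number from compound 1 to compound 2 (0.30 log units; within the scatter), is likewise within the scatter, so the three aryl substituents tried so far leave the read-out essentially unchanged.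

Compound 4 `NC(=O)c1c(NC(=O)c2cccc([N+](=O)[O-])c2)sc2c1CCN(C(=S)Nc1ccccc1Cl)C2` is not yet measured. It differs from compound 3 by 3-nitrophenyl in place of 2-methylphenyl on a carbonyl carbon. Within the data shown here, no measured step covers a nitro group, nor a move of the substituent to the place it occupies in 3-nitrophenyl, so the comparison rests only on the observation that fluoro, trifluoromethyl and methyl on that ring gave values within the scatter of one another. On that basis, compound 4 is expected to land close to compound 3, with the estimated step of a 1.1-fold higher number from compound 3 to compound 4 (0.04 log units; within the scatter) not exceeding the scatter in any clear direction. Compound 4 is therefore estimated at 12000 nM, with a range from 4000 nM to 40000 nM.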

Compound 4, half-maximal inhibitory concentration: 8850 nM
Compound 4: the middle estimate sits 1.4-fold (0.13 log units) above what was measured; the range from low to high includes it.
By their numbers in this assay, from the lowest: compounds 4, 3, 1 and 2 (each within the scatter of the next, the first and the last beyond it).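

Among these compounds, 3-nitrophenyl on the carbonyl carbon gives the only step beyond the scatter in this assay, a 2.5-fold lower number from compound 2 to compound 4 (0.39 log units; beyond the scatter), and this modest difference sets it apart only from 2-(trifluoromethyl)phenyl. Against the other two groups, the result is a 1.2-fold lower number from compound 3 to compound 4 (0.09 log units; within the scatter) and a 1.3-fold lower number from compound 1 to compound 4 (0.10 log units; within the scatter), so the position accepts a nitro-bearing ring with no clear separation from 2-methylphenyl or 2-fluorophenyl. Among these compounds, nothing available explains these values or the one step beyond the scatter.

The change from compound 3 to compound 4 alters both the group on the ring and its place, so the compounds shown leave open which of the two matters, if either does. They also leave open how this assay would read with an amine or a carboxylic acid on the ring, or with a longer alkyl chain in place of the aryl group on the carbonyl carbon.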